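This account rests on a few compounds, and the source may have more. Where it says the series, first, only, none or still open, it means among the compounds named here.

Measured compounds in an ADME assay on J774 cells (Mus musculus) for cytotoxicity, read by MTT assay, with a stated time of 24 h, tested at 10 uM; a higher number here means a weaker effect of the compound at the concentration tested, a lower number a stronger effect:
compound 1 `CCCCCCCCCCCO[C@@H]1[C@@H](N)[C@@H](O[C@H]2[C@H](O)[C@@H](OCCCCCCC)[C@H](N)C[C@@H]2N)O[C@H](CN)[C@H]1O` gives 88.4%
compound 2 `CCCCCCCO[C@@H]1[C@@H](O)[C@H](O[C@H]2O[C@H](CN)[C@@H](O)[C@H](O)[C@H]2N)[C@@H](N)C[C@H]1N` gives 84.3%
compound 3 `CCCCCCCCCCCO[C@@H]1[C@@H](O)[C@H](O[C@H]2O[C@H](CN)[C@@H](O)[C@H](OCCCCCCC)[C@H]2N)[C@@H](N)C[C@H]1N` gives 82.9%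

Compound 3 stands lowest of the three numbers in this assay; its nearest neighbour is compound 2 and its furthest is compound 1, and both gaps are within the scatter, so no order among the three can be claimed and none of them can be called the weaker or stronger.

Compound 4 `CCCCCCCO[C@@H]1[C@@H](N)[C@@H](O[C@H]2[C@H](O)[C@@H](OCCCCCCC)[C@H](N)C[C@@H]2N)O[C@H](CN)[C@H]1O` is not yet measured. It differs from compound 3 by hydrogen in place of butyl on a saturated chain carbon, seven bonds along the chain from an oxygen on a saturated carbon.

For the measured compounds named here, one measured step bears on this: a number 4.1 percentage points lower from compound 1 to compound 2 (within the scatter). There the whole undecyl chain was removed from an oxygen on a saturated carbon and the read-out in this assay did not move beyond the scatter. The change from compound 3 to compound 4 shortens a chain rather than removing it, and the remaining chain and the second heptyl chain are kept, so no step beyond the scatter is expected in this assay.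

For compound 4 the step of a number 2.1 percentage points higher from compound 3 to compound 4 (within the scatter) is expected to lie within the scatter. Compound 4 is estimated at 85% in this assay, with a range from 74% to 96%.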

Compound 4, a percentage reported as activity, at one concentration (the size of the read-out at that concentration, not a potency): 96.3%
Estimate against measurement, compound 4: 11.3 percentage points below; measured number above the stated range.
By their numbers in this assay, from the lowest: compounds 3, 2, 1 and 4 (each within the scatter of the next, the first and the last beyond it).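

Working notes on the series, read in this assay: hydrogen in place of butyl, on a saturated chain carbon seven bonds along the chain from an oxygen on a saturated carbon, gives a step beyond the scatter, a number 13.4 percentage points higher from compound 3 to compound 4 (beyond the scatter), and so a weaker effect at the concentration tested. The same printed change gives a number 7.9 percentage points higher from compound 1 to compound 4 (within the scatter), so its size at this place depends on the compound that carries it, and one step cannot be taken as a general rule for the chain. Heptyl in place of hydrogen on an oxygen on a saturated carbon also gives a step beyond the scatter, a number 12 percentage points higher from compound 2 to compound 4 (beyond the scatter), whereas the earlier change at such an oxygen, a number 4.1 percentage points lower from compound 1 to compound 2 (within the scatter), gave no step beyond it.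

Nothing given here accounts for these steps or for the difference between them. Still open is how the read-out behaves with a nonyl chain at this place or with a chain ending in an amine, since the compounds shown carry neither.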